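The compounds below may be only part of what the source reports. "The series", "measured", "known", "first", "only" and "open" are said of these compounds alone.

Compound 3 `CCn1c(=O)c2nc(-c3ccc(S(=O)(=O)N4CCSCC4)cc3)[nH]c2n(CC)c1=O` sets the highest of the three numbers recorded so far. In an assay for binding affinity to adenosine receptor A1 (Bos taurus) (on this read-out higher numbers stand for weaker inhibition and lower numbers for stronger inhibition), compound 3 gives 36.6 nM. Its nearest neighbour on this read-out is compound 1 `CCn1c(=O)c2nc(-c3cccc(S(=O)(=O)NCCN(C)C)c3)[nH]c2n(CC)c1=O`, which in this assay gives 29.4 nM, a gap that stays within the scatter, so the two cannot be told apart. The furthest is compound 2 `Cn1c(=O)c2nc(-c3cccc(F)c3)[nH]c2n(C)c1=O`, which in this assay gives 4 nM; that distance lies beyond the scatter, and compound 2 is the only one of the three built without the larger substituent on the phenyl ring attached to the shared core.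

Compound 4 `CCn1c(=O)c2nc(-c3ccc(S(=O)(=O)O)cc3)[nH]c2n(CC)c1=O` is not yet measured. It is reached from compound 3 by a single change: hydroxy in place of thiomorpholin-4-yl on a sulfonyl sulfur. Within the data shown here, no pair of measured compounds differs in just this way, so the size of the step has to be guessed from the numbers alone. He expects a step from compound 3 to compound 4 of an 11-fold higher number from compound 3 to compound 4 (1.04 log units; beyond the scatter), towards a higher number, with a real chance that the change lands within the scatter.

His estimate for compound 4 in this assay is 400 nM, with a range from 100 nM to 1500 nM.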

Compound 4, half-maximal inhibitory concentration: 755 nM
Compound 4: middle estimate off by 1.9-fold (0.28 log units), on the low side; low and high end bracket the measured number.
By their numbers in this assay, from the lowest: compound 2; then compounds 1 and 3 (each within the scatter of the next); then compound 4.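

In this assay, the group on the sulfonyl sulfur proves to matter a great deal: hydroxy in place of thiomorpholin-4-yl gives a large step beyond the scatter (a 21-fold higher number from compound 3 to compound 4 (1.31 log units; beyond the scatter)). Among these compounds, until now no two measured compounds differed in one place only, so this is the first change in the set whose size can be read directly, and it links the move from (thiomorpholin-4-yl)sulfonyl to sulfo with a clearly higher number on this read-out. Nothing measured here bears on why the step has this size or direction, so it stands as an observation without an explanation.

The step cannot say whether the higher number comes from losing the thiomorpholin-4-yl ring or from gaining hydroxy, a question that morpholine or a plain dimethylamino group on the same sulfonyl sulfur would help to separate. As far as these compounds go, it is also open whether a carboxylic acid in place of the sulfo group would give a number closer to that of compound 3 or to that of compound 4.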